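The source may hold more compounds than are shown below. What is called first, only, known or untested is meant among the compounds shown, and "the series" means these compounds.

Compound 1 `OB1OCc2ccc(-n3cccc3Sc3ccc(Cl)cc3)cc21`; compound 2 `OB1OCc2ccc(-n3cccc3Sc3ccccc3Cl)cc21`; compound 3 `OB1OCc2ccc(-n3cccc3Sc3ccc(Cl)c(Cl)c3)cc21`, not yet measured.

In an ADME assay on L929 cells (Mus musculus) for cytotoxicity, read by resazurin assay, with a stated time of 72 h (on this read-out higher numbers stand for weaker inhibition and lower numbers for stronger inhibition), compound 1 gives only a limit, > 10 ug/mL. In this assay compound 2 also gives only a limit, > 10 ug/mL. Both values sit at the limit of > 10 ug/mL in this assay, at which 2 of the 2 values shown sit, so compound 2 stands at that limit and no number places it. The change to compound 3 is 3,4-dichlorophenyl in place of 2-chlorophenyl on a sulfur. Among the compounds with values here, the only measured step, a step that the two limits leave unreadable from compound 1 to compound 2, lies between two limits and is unreadable, so it yields neither size nor direction. For compound 3 the expected step is a step that the limit leaves unreadable from compound 2 to compound 3, none beyond the scatter. Compound 3 is therefore expected at 20 ug/mL, between 10 ug/mL and 60 ug/mL, most probably reported again only as a limit.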

Compound 3, half-maximal inhibitory concentration: > 10 ug/mL
Compound 3: no number, only a limit; the forecaster's own chance of this, stated with the estimate: 85%; the middle value does not contradict the limit.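

No new step can be read among compound 1, compound 2 and compound 3 in this assay, since each gives only a limit: the limit of > 10 ug/mL in this assay, at which 3 of the 3 values shown sit. The compounds shown leave open where their actual values lie and whether the chlorophenyl changes on the sulfur alter them.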